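A few compounds are considered here, and "the series" means these few. Any claim that something is new, unique, unknown or untested is made for them only; others in the source may bear on it.

Measured so far in an assay on CHO cells for agonist activity at Neuronal acetylcholine receptor; alpha3/beta4 (Homo sapiens), read by FLIPR and calcium flux; on this read-out higher numbers stand for an effect only at larger amounts of compound and lower numbers for an effect already at smaller amounts:
compound 1, `C[C@@H]1C[C@@H]1C(=O)N1CC2CNCC2C1`, gives 1400 nM
compound 2, `C[C@H]1C[C@@H]1C(=O)N1CC2CNCC2C1`, gives 34000 nM
compound 3, `O=C(C1CC1)[C@H]1C[C@H]2CNC[C@H]2C1`, gives 930 nM

Compound 3 and compound 1 give numbers that lie within the usual scatter of each other, so the two cannot be told apart on this read-out; compound 2 stands far beyond both of them. Going by the values given here, the only step between measured compounds that differ in one place is a 24-fold higher number from compound 1 to compound 2 (1.39 log units; beyond the scatter). That step rests on a stereochemical difference alone, noted as the fact that one of compounds 1 and 2 is drawn with a defined configuration and the other without, at the place where they differ, and touches no group on the carbonyl carbon.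

Compound 4, `O=C(c1ccco1)[C@H]1C[C@H]2CNC[C@H]2C1`, differs from compound 3 by furan-2-yl in place of cyclopropyl on a carbonyl carbon. Among the compounds with values here, no measured step changes the group on the carbonyl carbon: the step from compound 1 to compound 2 concerns a stereocentre and so gives no guide to what a furan-2-yl in place of a cyclopropyl does. With nothing in the data pointing either way, the expected change is none beyond the scatter, with a wide margin in both directions. The estimated step is a 1.2-fold higher number from compound 3 to compound 4 (0.07 log units; within the scatter). Compound 4 is therefore expected to give 1100 nM in this assay, within a range from 300 nM to 4500 nM.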

Compound 4, half-maximal effective concentration: 11000 nM
Compound 4: the middle estimate sits 10-fold (1.00 log units) below what was measured; the measured number lies above the stated range.
By their numbers in this assay, from the lowest: compounds 3 and 1 (each within the scatter of the next); then compound 4; then compound 2.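

In this assay, going by these compounds alone, furan-2-yl in place of cyclopropyl on a carbonyl carbon gives a 12-fold higher number from compound 3 to compound 4 (1.07 log units; beyond the scatter), so the group at this place clearly affects the read-out, which the earlier compounds could not show. Within the data shown here, until now the only step between compounds differing in one place concerned a stereocentre, and with a 24-fold higher number from compound 1 to compound 2 (1.39 log units; beyond the scatter) beside the new step, a change of group here and a change of that stereocentre each move the number beyond the scatter. Furan-2-yl is a five-membered aromatic ring with one oxygen and one hydrogen-bond acceptor, whereas cyclopropyl is a three-membered non-aromatic ring of carbon only with no acceptor, and nothing given here tells which of these differences lies behind the step.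

The compounds shown leave open whether the higher number goes with the aromatic ring, the ring oxygen or simply the larger ring. Phenyl, cyclopentyl or tetrahydrofuran-2-yl on the same carbonyl carbon would pull these apart, while an amine or a longer carbon chain there would show how far the position tolerates other kinds of group.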